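The compounds below may be only part of what the source reports. "The series", "measured", "known", "first", "only" and "open" are said of these compounds alone.

Working notes on an amide series acting at an assay on HEK293 cells for agonist activity at transient receptor potential cation channel subfamily M member 8 (Homo sapiens), read by fluorescence and calcium flux, with a stated time of 15 min; a higher number here means that more compound is needed for the effect, a lower number that less compound is needed. Compound 1, `CCN(Cc1cccs1)C(=O)COc1cc(C)ccc1O`, gives 24 nM in this assay. Going by the values given here, compound 2, `Cc1ccc(OCC(=O)N(Cc2cccs2)C2COC2)cc1`, gives 23000 nM in this assay and so stands at the highest number of the two measured so far; the gap to compound 1 lies far beyond the scatter, but the two structures differ in more than one place, so no single change can be read from that gap. The next compound in the series is compound 3, `Cc1ccc(OCC(=O)N(Cc2cccs2)C2CC2)cc1`, still to be measured in this assay. Compound 3 differs from compound 2 by cyclopropyl in place of oxetan-3-yl on an amide-type nitrogen. Among the compounds with values here, no measured pair shows this change on its own, so its size has no direct precedent here; the only guide is that compound 2 sits far above compound 1 in this assay, which leaves room for a move downward. A moderate step downward, beyond the scatter, is expected: a 3.8-fold lower number from compound 2 to compound 3 (0.58 log units; beyond the scatter). Compound 3 is accordingly estimated at 6000 nM in this assay, with a range from 1500 nM to 25000 nM.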

Compound 3, half-maximal effective concentration: 8 nM
The estimate for compound 3 lay 750-fold (2.88 log units) above the measured number; measured number outside the range, below it.
By their numbers in this assay, from the lowest: compound 3; then compound 1; then compound 2.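

At the amide-type nitrogen whose other neighbours are the carbonyl carbon and a saturated chain carbon, the substituent alone has a very large effect in this assay: cyclopropyl in place of oxetan-3-yl gives a 2900-fold lower number from compound 2 to compound 3 (3.46 log units; beyond the scatter) and so lies beyond the scatter. Going by these compounds alone, this is the first change that can be read in one place, and it shows that this position is highly sensitive to the group it carries. The change replaces a four-membered non-aromatic ring with one hetero atom and one hydrogen-bond acceptor by a three-membered non-aromatic ring of carbon only, but nothing measured bears on what lies behind the size of the step.

The compounds shown do not separate the loss of the ring oxygen from the change in ring size; cyclobutyl on the same nitrogen would keep the four-membered ring without the oxygen and so pull the two apart. Also open, as far as these compounds go, is how an open chain such as isopropyl would behave at this position on the core of compound 3, and whether the same exchange would give a step of similar size on the core of compound 1.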